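Removing the ethyl group of compound 3: cytotoxicity expected unchanged

A few compounds are considered here, and "the series" means these few. Any claim that something is new, unique, unknown or untested is made for them only; others in the source may bear on it.

Of the compounds shown here, three on a shared core have been tested in a functional assay on Vero cells (Chlorocebus sabaeus) for cytotoxicity, read by MTT assay; on this read-out lower numbers stand for higher toxicity in this test and higher numbers for lower toxicity in this test. Compound 1 `O=c1[nH]c(=O)n(COCCO)cc1[N+](=O)[O-]` reaches only the edge of the test: in this assay compound 1 gives > 432000 nM, a limit and not a number. Compound 2 `Nc1cn(COCCO)c(=O)[nH]c1=O` likewise gives > 497000 nM in this assay, again a limit. The step that the two limits leave unreadable from compound 1 to compound 2 thus cannot be read. Compound 3 `CCc1cn(COCCO)c(=S)[nH]c1=O` stands at the same kind of edge: in this assay compound 3 gives > 478000 nM, which is a limit rather than a number. All three values sit at limits, as the limit of > 432000 nM in this assay, at which 1 of the 3 values shown sits, the limit of > 478000 nM in this assay, at which 1 of the 3 values shown sits, and the limit of > 497000 nM in this assay, at which 1 of the 3 values shown sits, record.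

Compound 4 `O=c1ccn(COCCO)c(=S)[nH]1` differs from compound 3 in one place: hydrogen in place of ethyl on an aromatic carbon. Going by the values given here, no measured step bears on this change; the only step available lies between two limits and gives no size. With every measured neighbour at a limit, no movement beyond the usual scatter is expected in this assay. The step that the limit leaves unreadable from compound 3 to compound 4 is expected to be small or absent. Compound 4 is therefore estimated at 500000 nM, with a range from 200000 nM to 1200000 nM, and is most likely to be reported once more as a limit.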

Compound 4, half-maximal cytotoxic concentration: > 495000 nM
Compound 4: no number, only a limit (the forecaster's own chance of this, stated with the estimate: 85%); the middle value is on the limit's open side.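

In this assay compound 4 gives > 495000 nM, a limit and not a number. Compound 3 also stands at a limit, so no size can be read for the change from compound 3 to compound 4. The compounds shown leave open whether any change on the shared core moves the cytotoxicity in this assay at all.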